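A few compounds are considered here, and "the series" means these few. Any claim that something is new, unique, unknown or untested is made for them only; others in the source may bear on it.

Measured compounds:
compound 1 `COc1nn(Cc2cccc([N+](=O)[O-])c2)c(=O)o1`: 7%
compound 2 `COc1nn(Cc2ccccc2NC(=O)c2ccccc2)c(=O)o1`: "not active" (no number reported)

For the measured compounds named here, in an assay on COS-7 cells for inhibition of Fatty-acid amide hydrolase 1 (Homo sapiens), read by scintillation counting, with a stated time of 10 min, tested at 10 uM (a higher number here means more inhibition at the concentration tested (going by the name of the read-out), a lower number less inhibition), compound 1 gives 7%, the only number reported in this set. In this assay compound 2 is reported as "not active" (no number reported), without a number. Compound 3 `COc1nn(Cc2cccc(C(F)(F)F)c2)c(=O)o1` differs from compound 1 by trifluoromethyl in place of nitro on an aromatic carbon. Going by the values given here, no step between measured compounds is available to gauge such a change, so in this assay the step from compound 1 to compound 3 is expected to stay within the usual scatter, with no clear direction. Compound 3 is therefore expected to give about 8%, between -6% and 24%. The expected step is a number 1 percentage points higher from compound 1 to compound 3 (within the scatter).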

Compound 3, a percentage reported as inhibition, at one concentration (the size of the read-out at that concentration, not a potency): 12%
Compound 3: middle estimate off by 4 percentage points, on the low side; the range from low to high includes it.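

In this assay, trifluoromethyl in place of nitro on this aromatic carbon gives a number 5 percentage points higher from compound 1 to compound 3 (within the scatter). For the compounds shown here, this is the first step that can be read at this position, and it shows that exchanging nitro for trifluoromethyl, which takes away the two hydrogen-bond acceptors counted for nitro, leaves the read-out within the scatter. No measurement at hand bears on this result.

As far as these compounds go, whether an amine or a carboxylic acid on this carbon would move the read-out beyond the scatter remains open. Steps involving compound 2 cannot be read.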